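The source may hold more compounds than are shown below. What is called first, only, known or untested is meant among the compounds shown, and "the series" means these compounds.

Measured compounds in a functional assay on Bel-7402 cells (Homo sapiens) for cytotoxicity, read by sulforhodamine B assay, with a stated time of 24 h; a higher number here means a weaker inhibitor, a lower number a stronger inhibitor:

compound 1, `C=CC(C)(C)c1[nH]c2ccc(C[C@@H](Cl)C(C)(C)O)cc2c1/C=C1\NC(=O)[C@H](C)NC1=O`: > 50000 nM, a limit of the assay and not a number
compound 2, `C=CC(C)(C)c1[nH]c2ccc(CC(=O)C(C)C)cc2c1/C=C1\NC(=O)[C@H](C)NC1=O`: > 50000 nM, a limit of the assay and not a number
compound 3, `C=CC(C)(C)c1[nH]c2c(C[C@@H](O)C(C)(C)Cl)cccc2c1/C=C1\NC(=O)[C@H](C)NC1=O`: > 50000 nM, a limit of the assay and not a number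

Going by the values given here, compound 3 therefore stands where every measured compound here stands: at the limit of > 50000 nM in this assay, at which 3 of the 3 values shown sit, so no measured compound has a true number in this assay. The next compound, compound 4, is `C=CC(C)(C)c1[nH]c2c(CC=C(C)C)cccc2c1/C=C1\NC(=O)[C@H](C)NC1=O`. It differs from compound 3 in one place: 2-methylprop-1-en-1-yl in place of 2-chloro-1-hydroxy-2-methylpropyl on a saturated chain carbon bound to an aromatic carbon.

Among the compounds with values here, only one measured step changes the same kind of side chain, the step that the two limits leave unreadable from compound 1 to compound 2, and its size cannot be read, since both ends sit at the limit. No step with a readable size bears on the change from compound 3 to compound 4, so no direction beyond the scatter can be expected from the numbers shown.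

On that basis compound 4 is expected to give about 60000 nM, with a range from 15000 nM to 250000 nM, and most likely once more only a limit. The expected step is a step that the limit leaves unreadable from compound 3 to compound 4.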

Compound 4, half-maximal inhibitory concentration: > 50000 nM
Compound 4: a limit, no number; the forecaster's own chance of this, stated with the estimate: 80%; the middle value does not contradict the limit.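

Compound 4 gives > 50000 nM, a limit of the assay and not a number. Compound 3 also sits at a limit, so no size can be read for the change between compound 3 and compound 4. The compounds shown leave open how strongly any of them inhibits, and whether any of these side chains matters: the limit of > 50000 nM in this assay, at which 4 of the 4 values shown sit.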